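The source may hold more compounds than are shown below. What is called first, only, known or untested is meant among the compounds shown, and "the series" means these compounds.

Among the measured compounds shown here, in a functional assay on PC-12 cells (Rattus norvegicus) for inhibition, read by sulforhodamine B assay (on this read-out higher numbers stand for weaker inhibition and lower numbers for stronger inhibition), compound 2 `CCC(C)(C)Oc1ccc(CC2SC(=O)NC2=O)cc1` gives 23000 nM, the only true number so far. Compound 1 `O=C1NC(=O)C(Cc2ccc(OCC3CCC3)cc2)S1` gives > 100000 nM, which is a limit. Compound 3 `O=C1NC(=O)C(Cc2ccccc2)S1` gives > 100000 nM, also a limit. Compound 4 `O=C1NC(=O)C(Cc2ccc(OCc3ccccc3)cc2)S1` differs from compound 2 as follows: benzyl in place of 1,1-dimethylpropyl on an oxygen on an aromatic ring. For the measured compounds named here, two measured steps bear on this change: an at least 4.3-fold lower number from compound 1 to compound 2 (0.63 log units; beyond the scatter), and an at least 4.3-fold higher number from compound 2 to compound 3 (0.63 log units; beyond the scatter). As far as these compounds go, both are bounded by a limit, so their true sizes remain open. Benzyl, like cyclobutylmethyl in compound 1 at > 100000 nM, contains a ring, so a move towards a higher number is expected. The expected step is a 2.2-fold higher number from compound 2 to compound 4 (0.34 log units; beyond the scatter), which is modest. Compound 4 is estimated at 50000 nM, within an expected range of 15000 nM to 150000 nM.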

Compound 4, half-maximal inhibitory concentration: > 100000 nM
Compound 4 was reported as a limit; the forecaster's own chance of this, stated with the estimate: 45%; middle value at least 2.0-fold (0.30 log units) away from the limit.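

In this assay, among the compounds shown here, benzyl in place of 1,1-dimethylpropyl on the oxygen gives an at least 4.3-fold higher number from compound 2 to compound 4 (0.63 log units; beyond the scatter), so a second ring-bearing group on this oxygen now stands apart from compound 2, the only compound with a true number. The value of compound 4, > 100000 nM, is a limit. The step from compound 1 to compound 4 cannot be read, so benzyl and cyclobutylmethyl cannot be ordered, and the series has one point of reference: the limit of > 100000 nM in this assay, at which 3 of the 4 values shown sit.

As far as these compounds go, it remains open whether the ring or the lost branching goes with this step. A straight pentyl chain on the same oxygen would separate the two.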